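Chain methyl removal in the pyridazinone thioamide series

The compounds below may be only part of what the source reports. "The series", "measured", "known", "first", "only" and "open" are said of these compounds alone.

The series shares one core: compound 1 `N=C(S)CCn1nc(-c2cccs2)ccc1=O`, compound 2 `N=C(S)CCn1ncccc1=O` and compound 3 `Cc1ccc(=O)n(C(C)CC(=N)S)n1`. In a functional assay on the whole organism (stomach) for inhibition, with Rattus norvegicus as the target, at a dose of 100 mg/kg by the intraduodenal route (on this read-out higher numbers stand for more inhibition at the one dose given (going by the name of the read-out) and lower numbers for less inhibition), compound 1 gives 50.2%, compound 2 gives 28.8% and compound 3 gives 32.5%. Compound 3 sits with compound 2 within the scatter and below compound 1 beyond it. Going by the values given here, the one step that differs in a single place, a number 21.4 percentage points lower from compound 1 to compound 2 (beyond the scatter), concerns a substituent on the aromatic carbon and not the chain.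

Compound 4 `Cc1ccc(=O)n(CCC(=N)S)n1` differs from compound 3 by hydrogen in place of methyl on a saturated chain carbon bound to an aromatic nitrogen and a saturated chain carbon. Among the compounds with values here, no measured step touches this chain carbon, so nothing bears directly on it; the only measured step is of modest size and at another position. The working expectation is therefore no step beyond the scatter, as expressed by the estimated step of a number 0.5 percentage points lower from compound 3 to compound 4 (within the scatter). Compound 4 is accordingly expected to give about 32% in this assay, within a range from 15% to 48%.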

Compound 4, a percentage reported as inhibition, in the whole organism at one dose (the size of the read-out at that dose, not a potency): 73.9%
Compound 4: middle estimate off by 41.9 percentage points, on the low side; the measured number lies above the stated range.
By their numbers in this assay, from the lowest: compounds 2 and 3 (each within the scatter of the next); then compound 1; then compound 4.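

In this assay, going by these compounds alone, the chain carbon proves to be a sensitive place: hydrogen in place of methyl there gives a large step at a position no earlier step touched (a number 41.4 percentage points higher from compound 3 to compound 4 (beyond the scatter)). With that carbon unbranched, the earlier order at the aromatic carbon also gains a new member, since methyl stands above both hydrogen (a number 45.1 percentage points higher from compound 2 to compound 4 (beyond the scatter)) and thiophen-2-yl (a number 23.7 percentage points higher from compound 1 to compound 4 (beyond the scatter)), which puts compound 4 highest of the four, beyond the scatter from each of the others. Nothing measured on these compounds explains why the chain methyl has so large an effect on this read-out.

Open, from the compounds shown here alone, is whether an ethyl or a hydroxyl on the same chain carbon would also give a lower number than hydrogen. Also open, going by these compounds, is whether hydrogen in place of methyl at the chain carbon gives a comparable step when the aromatic carbon carries thiophen-2-yl or hydrogen.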